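Adding methoxy to compound 2: an expected step

A few compounds are considered here, and "the series" means these few. Any claim that something is new, unique, unknown or untested is made for them only; others in the source may bear on it.

Values in a functional assay on HepG2 cells (Homo sapiens) for antiproliferative activity, read by sulforhodamine B assay, with a stated time of 48 h; on this read-out higher numbers stand for weaker inhibition and lower numbers for stronger inhibition:
- compound 1 `COc1ccc(/C=C/C(=O)c2ccccc2-c2ccc(F)cc2)cc1B(O)O`: 30 nM
- compound 2 `COc1ccc(C(=O)/C=C/c2ccccc2-c2ccc(F)cc2)cc1`: 6300 nM
- compound 3 `COc1ccc(C(=O)/C=C/c2ccccc2-c2ccc(F)nc2)cc1`: 8200 nM

In this assay compound 2 gives 6300 nM, at the weak end of the numbers shown, while compound 1 gives a far lower 30 nM. Compound 4 `COc1ccc(C(=O)/C=C/c2ccccc2-c2ccc(F)cc2)cc1OC` departs from compound 2 by a single change, methoxy in place of hydrogen on an aromatic carbon. For the measured compounds named here, no measured pair shows this change. Going by the values given here, the only measured step is a 1.3-fold higher number from compound 2 to compound 3 (0.11 log units; within the scatter), and it swaps 4-fluorophenyl for 6-fluoropyridin-3-yl, so it bears on the question only indirectly. Compound 1 differs from compound 2 in more than one place, and its value cannot be assigned to any single change. With no evidence for a large shift, no step beyond the scatter is expected in this assay, although the uncertainty is wide. The estimated step is a 1.3-fold lower number from compound 2 to compound 4 (0.10 log units; within the scatter). Compound 4 is estimated at 5000 nM, with an expected range of 1800 nM to 14000 nM.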

Compound 4, half-maximal inhibitory concentration: 6600 nM
The estimate for compound 4 lay 1.3-fold (0.12 log units) below the measured number; low and high end bracket the measured number.
By their numbers in this assay, from the lowest: compound 1; then compounds 2, 4 and 3 (each within the scatter of the next).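

In this assay, for the compounds shown here, the change of methoxy in place of hydrogen on an aromatic carbon, ortho to a methoxy group, gives a 1.0-fold higher number from compound 2 to compound 4 (0.02 log units; within the scatter) and so provides the first direct reading of this change. The two numbers cannot be told apart, so this place on the six-membered aromatic ring of carbon only accepts a second methoxy with no step beyond the scatter. Compound 2 and compound 4 thus form a pair in which this one added group shows no measurable effect on the read-out.

On these data alone, whether another group at this same place, such as an amine, a carboxylic acid or a longer ethoxy chain, would give a step beyond the scatter stays open. No independent measurement is available to explain why this step is so small.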